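Swapping bromo for methoxy on a shared phenyl ring

A few compounds are considered here, and "the series" means these few. Any claim that something is new, unique, unknown or untested is made for them only; others in the source may bear on it.

Compound 1, `CC(=N)Nc1cccc(C(=O)NNC(=O)CC(CC(=O)O)c2ccc(Br)cc2)c1`, and compound 2, `COc1ccc(C(CC(=O)O)CC(=O)NNC(=O)c2cccc(NC(C)=N)c2)cc1`, differ in a single place. In a physicochemical assay for lipophilicity (a lower number here means a more polar compound, a higher number a more lipophilic compound), compound 1 gives 2.27, while compound 2 gives 1.31. The structural change between them is methoxy in place of bromo on an aromatic carbon, and it produced a number 0.96 log units lower from compound 1 to compound 2 (beyond the scatter).

Compound 3, `O=C(O)CC(CC(=O)NNC(=O)CCCCNc1ccccn1)c1ccc(Br)cc1`, carries the same bromo group on a different core; the difference between the two cores is not broken down here. In this assay compound 3 gives 2.9, the highest of the three numbers.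

Compound 4, `COc1ccc(C(CC(=O)O)CC(=O)NNC(=O)CCCCNc2ccccn2)cc1`, has not yet been measured. It differs from compound 3 by methoxy in place of bromo on an aromatic carbon, which is the same change seen between compound 1 and compound 2, at the same place on the ring.

Because the earlier example gave a number 0.96 log units lower from compound 1 to compound 2 (beyond the scatter), the step from compound 3 to compound 4 is expected to be a number 0.96 log units lower from compound 3 to compound 4 (beyond the scatter). Compound 4 is therefore estimated at 1.94, with a range from 1.5 to 2.4. The estimate rests on one earlier example only, so the range is kept wide.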

Compound 4, partition coefficient: 1.94
Beside the measured number, compound 4's estimate shows no gap at the digits printed; the measured number falls inside the stated range.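

In this assay methoxy in place of bromo gave a number 0.96 log units lower from compound 3 to compound 4 (beyond the scatter) on one core and a number 0.96 log units lower from compound 1 to compound 2 (beyond the scatter) on the other core, so the two steps match at the digits printed. For these two pairs, then, the size of the step carried over from one core to the other, even though the two bromo compounds start from different values; two pairs are still too few to show that a third core would behave the same way. Nothing presented here explains the size of the step or the match between the two cores.

As far as these compounds go, it remains open whether other groups at the same place on the ring, para to a large group, such as chloro, methyl or an amine, would also give steps that carry over between these cores. From the compounds shown here alone, it is equally open whether the methoxy for bromo step would stay the same on a core with an ester in place of the carboxylic acid.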